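The compounds below may be only part of what the source reports. "The series", "measured", "known", "first", "only" and "open" are said of these compounds alone.

Measured so far:
Compound 1 `COc1cc(C2Oc3cc([C@H]4Oc5cc(O)cc(O)c5C(=O)[C@@H]4O)ccc3OC2COC(=O)c2ccc(OC)c(OC)c2)ccc1O` gives 16000 nM in a functional assay on liver (Rattus norvegicus, strain Sprague-Dawley) for inhibition, with a stated time of 1 h; on this read-out higher numbers stand for weaker inhibition and lower numbers for stronger inhibition.
Compound 2 `COc1cc(C2Oc3cc([C@H]4Oc5cc(O)cc(O)c5C(=O)[C@@H]4O)ccc3OC2COC(=O)c2ccc(N)cc2)ccc1O` gives 14300 nM in this assay.

Compound 2 holds the lower of the two numbers, but the step of a 1.1-fold lower number from compound 1 to compound 2 (0.05 log units; within the scatter) is within the scatter, so the two compounds cannot be told apart on this read-out. Both share the same core and differ only in the group on the carbonyl carbon of the ester.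

Compound 3 `COc1cc(C2Oc3cc([C@H]4Oc5cc(O)cc(O)c5C(=O)[C@@H]4O)ccc3OC2COC(=O)/C=C/c2ccc(C)cc2)ccc1O` differs from compound 2 at the same place: 2-(4-methylphenyl)ethenyl in place of 4-aminophenyl on a carbonyl carbon. Among the measured compounds shown here, the only measured step that bears on this position is a 1.1-fold lower number from compound 1 to compound 2 (0.05 log units; within the scatter), in which a different group on the same carbonyl carbon left the number essentially unchanged. Nothing measured here distinguishes one ester group from another at this place, so for compound 3 no step beyond the scatter is expected in this assay, in either direction; the step of a 1.0-fold lower number from compound 2 to compound 3 (0.01 log units; within the scatter) is the expected outcome. Compound 3 is therefore estimated at 14000 nM in this assay, with a range from 5000 nM to 40000 nM.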

Compound 3, half-maximal inhibitory concentration: 14700 nM
For compound 3 the middle estimate is 1.1-fold (0.02 log units) below the measured one; the measured number falls inside the stated range.
By their numbers in this assay, from the lowest: compounds 2, 3 and 1 (each within the scatter of the next).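

Working notes on the ester position, read in this assay: with 2-(4-methylphenyl)ethenyl in place of 4-aminophenyl on a carbonyl carbon the step is a 1.0-fold higher number from compound 2 to compound 3 (0.01 log units; within the scatter) and with the same group in place of 3,4-dimethoxyphenyl the step is a 1.1-fold lower number from compound 1 to compound 3 (0.04 log units; within the scatter). Compound 3 extends the comparison beyond the earlier pair: the entering group brings a double bond outside aromatic rings and has neither the hydrogen-bond donor nor the hydrogen-bond acceptor counted for 4-aminophenyl, yet neither step leaves the scatter, so these differences in the ester group have no measurable consequence on this read-out within these three compounds. No supporting evidence is available on why the three esters read alike.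

All three ester groups shown carry a six-membered aromatic ring of carbon only, so the reading for a group without such a ring, such as a saturated alkyl chain or a carboxylic acid, remains open. Also open, from the compounds shown here alone, is whether the free alcohol in place of the ester, or any change to the shared core, would move the number beyond the scatter.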